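A few compounds are considered here, and "the series" means these few. Any claim that something is new, unique, unknown or untested is made for them only; others in the source may bear on it.

Of the compounds shown here, three built on a shared core have been tested in an assay on isolated protein for inhibition of Indoleamine 2,3-dioxygenase 1 (Homo sapiens), read by spectrophotometry; on this read-out lower numbers stand for stronger inhibition and higher numbers for weaker inhibition. Compound 1 `O=C(Cc1ccncc1)c1cc2ccccc2[nH]1` gives "not active" (no number reported) in this assay. Compound 3 `OC(Cc1cccnc1)c1cc2ccccc2[nH]1` also gives "not active" (no number reported) in this assay. Compound 2 `O=C(Cc1cccnc1)c1cc2cc(Br)ccc2[nH]1` gives 18000 nM in this assay, which makes it the only one of the three with an actual number, and that number points to weak inhibition.

Compound 4 `O=C(Cc1cccnc1)c1cc2cc(OC(F)(F)F)ccc2[nH]1` has not yet been measured. It differs from compound 2 in a single place: trifluoromethoxy in place of bromo on an aromatic carbon. Going by the values given here, no pair of measured compounds differing in only one place is available, so nothing yet shows how a change at this place moves the read-out. With a single weak number as the only anchor, the step is expected to be small, either direction or none beyond the scatter. In this assay the expected step is a 1.1-fold higher number from compound 2 to compound 4 (0.05 log units; within the scatter). Compound 4 is expected to give about 20000 nM in this assay, within a range from 6000 nM to 60000 nM.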

Compound 4, half-maximal inhibitory concentration: 13100 nM
Compound 4: the middle estimate sits 1.5-fold (0.18 log units) above what was measured; low and high end bracket the measured number.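

In this assay, placing trifluoromethoxy instead of bromo on this aromatic carbon gives a 1.4-fold lower number from compound 2 to compound 4 (0.14 log units; within the scatter), so the read-out cannot tell the two compounds apart. Going by these compounds alone, this is the first comparison in which only one place changes, and it shows that a group of five heavy atoms, including a hydrogen-bond acceptor, can stand where a single bromine stood while inhibition remains measurable and weak. Nothing available explains why this change leaves the result within the scatter.

The compounds shown leave open whether an amine, a carboxylic acid or a methyl group on this carbon would move the number beyond the scatter. Also open, from the compounds shown here alone, is whether a bare hydrogen there, with the rest of compound 2 unchanged, would give a measurable number at all.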